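The compounds below may be only part of what the source reports. "The series", "measured", "known", "first", "only" and "open" are said of these compounds alone.

In a functional assay on HeLa cells (Homo sapiens) for cytotoxicity, read by MTT assay, with a stated time of 48 h (a higher number here means a weaker inhibitor, a lower number a stronger inhibitor), three compounds have been measured so far. Compound 1 `COc1cc([C@@H]2C[C@]2(CO)C(=O)Nc2ccccc2Cl)cc(OC)c1OC` gives 8100 nM. Compound 2 `CCOC(=O)[C@@]1(C(=O)Nc2ccccc2Cl)C[C@@H]1c1cc(OC)c(OC)c(OC)c1` reads > 100000 nM, which is a limit of the assay and not a number. Compound 3 `COc1cc([C@H]2C[C@]2(CO)C(=O)Nc2ccccc2Cl)cc(OC)c1OC` gives 45500 nM, the higher of the two actual numbers, so it is the weaker inhibitor of that pair.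

Compound 4 `COc1cc([C@H]2C[C@@]2(CO)C(=O)Nc2ccccc2Cl)cc(OC)c1OC` has not yet been measured. Its difference from compound 3 is this: the two compounds have the same atoms and bonds and differ only in configuration as drawn: 1 of 2 stereo elements differ; a stereocentre at a saturated ring carbon is drawn S in compound 3 and R in compound 4. Thus a stereocentre at a saturated ring carbon is drawn S in compound 3 and R in compound 4.

Going by the values given here, one measured step bears on this change: a 5.6-fold higher number from compound 1 to compound 3 (0.75 log units; beyond the scatter). It also involves configuration alone, and it shows that such a change can move the number beyond the scatter. It suggests a size but does not settle the direction. Since compound 3 already stands high at 45500 nM, a step no larger than that one, leaning towards a lower number, is expected. The expected step is a 1.8-fold lower number from compound 3 to compound 4 (0.26 log units; within the scatter). For compound 4, the estimated value is 25000 nM, with an expected range of 7000 nM to 90000 nM.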

Compound 4, half-maximal inhibitory concentration: > 100000 nM
Compound 4 gave a limit, no number; the forecaster's own chance of this, stated with the estimate: 20%; middle value at least 4.0-fold (0.60 log units) away from the limit.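

In this assay, inverting the second stereocentre of compound 3 gives an at least 2.1-fold higher number from compound 3 to compound 4 (0.34 log units; beyond the scatter), so both ring stereocentres of this series now show a step beyond the scatter, and this one leaves the atoms and bonds untouched. Inverting both stereocentres together gives the mirror image and an at least 12-fold higher number from compound 1 to compound 4 (1.09 log units; beyond the scatter), a large step that ties the cell result to the three-dimensional arrangement alone, as this fact shows: the fact that compounds 1 and 4 differ only in the configuration as drawn. Compound 4 sits at a limit of the assay and not at a number, so these two steps give minimum sizes only.

The step between compound 2 and compound 4 cannot be read, as both values are limits. As far as these compounds go, whether an amine or a carboxylic acid in place of hydroxymethyl would hold up in the arrangement of compound 1 remains open.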